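Branching the side chain in a cyclohexylamide series

The source may report more compounds than this note shows. Statements on the series, on what has been measured and on what is new or still open speak of the compounds shown alone.

Going by the values given here, compound 1 `CC(C)C(NC(=O)NO)C(=O)NC1CCCCC1` is the only member with a number so far: in a functional assay on WI-38 cells (Homo sapiens) for inhibition (a higher number here means a weaker inhibitor, a lower number a stronger inhibitor), compound 1 gives 58800 nM. Compound 2 `CCC(C)C1NC(=O)N(C2CCCCC2)C1=O` returns no number in this assay but a limit of the assay, > 100000 nM, which is the limit of > 100000 nM in this assay, at which 1 of the 2 values shown sits. Compound 3 `CCC(C)C(NC(=O)NO)C(=O)NC1CCCCC1` remains to be measured. Against compound 1 the change is methyl in place of hydrogen on a saturated chain carbon, three bonds along the chain from an amide-type nitrogen and a carbonyl carbon, read one bond further out as isopropyl to sec-butyl. Among the compounds with values here, no measured pair covers this change, so the step in this assay is expected to stay within the usual scatter, with no clear direction. For compound 3 the estimate is 50000 nM, in the range 15000 nM to 150000 nM. This corresponds to an expected 1.2-fold lower number from compound 1 to compound 3 (0.07 log units; within the scatter).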

Compound 3, half-maximal inhibitory concentration: > 100000 nM
Compound 3 gave a limit, no number; the forecaster's own chance of this, stated with the estimate: 25%; middle value at least 2.0-fold (0.30 log units) away from the limit.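

In this assay, methyl in place of hydrogen on this saturated chain carbon, isopropyl to sec-butyl, gives an at least 1.7-fold higher number from compound 1 to compound 3 (0.23 log units; that floor lies within the scatter), which is a floor and not a measured size. Compound 3 gives a limit, > 100000 nM, not a number. This first step at the position shows no stronger inhibitor with sec-butyl, and the read-out gives no true size for the change: the limit of > 100000 nM in this assay, at which 2 of the 3 values shown sit.

As far as these compounds go, how far the number rises with sec-butyl remains open. Also open, from the compounds shown here alone, is how an ethyl group or a carboxylic acid on this chain carbon would read against compound 1.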